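This account rests on a few compounds, and the source may have more. Where it says the series, first, only, none or still open, it means among the compounds named here.

Three compounds were measured in an assay on nucleic acid for binding affinity to Salmon testes DNA (Salmonidae), tested at 10 uM; a higher number here means that the compound stabilises the target more against heat, a lower number that the compound stabilises the target less. Compound 2 `CC(C)CCc1sc(NC(=O)c2cc(NC(=O)c3cc(NC(=N)c4ccccc4)cn3C)cn2C)nc1C(=O)NCCCN(C)C` gives 7 degrees C. Compound 1 `CC(C)CCc1sc(NC(=O)c2cc(NC(=O)c3cc(NC(=N)c4cnc5ccccc5c4)cn3C)cn2C)nc1C(=O)NCCCN(C)C` differs from compound 2 by quinolin-3-yl in place of phenyl on a carbon with a double bond to nitrogen, and in this assay compound 1 gives 2 degrees C, a step of a number 5.0 degrees C lower from compound 2 to compound 1 (beyond the scatter). Compound 3 `CN(C)CCCNC(=O)c1cc(NC(=O)c2cc(NC(=O)c3cc(NC(=N)c4ccccc4)cn3C)cn2C)cn1C` has another core; the difference between the two cores is not broken down here. In this assay compound 3 gives 11 degrees C, the highest of the three. Compound 4 `CN(C)CCCNC(=O)c1cc(NC(=O)c2cc(NC(=O)c3cc(NC(=N)c4cnc5ccccc5c4)cn3C)cn2C)cn1C` differs from compound 3 by quinolin-3-yl in place of phenyl on a carbon with a double bond to nitrogen, the same change at the same place as that from compound 2 to compound 1. Compound 4 is expected to show a step of similar size, a number 5.0 degrees C lower from compound 3 to compound 4 (beyond the scatter), because a number 5.0 degrees C lower from compound 2 to compound 1 (beyond the scatter) came from the same change. Compound 4 is therefore estimated at 6 degrees C, expected between 3 degrees C and 9 degrees C.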

Compound 4, shift of the target's melting temperature: > 17 degrees C
Compound 4 gave a limit, no number; the forecaster's own chance of this, stated with the estimate: 0%; middle value at least 11 degrees C away from the limit.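

In this assay compound 4 gives > 17 degrees C, which is a limit of the assay and not a number. Quinolin-3-yl in place of phenyl gives a number at least 6.0 degrees C higher from compound 3 to compound 4 (beyond the scatter), and the change does not carry over from one core to the other: the same change on two cores in this assay, a number 5.0 degrees C lower (beyond the scatter) from compound 2 to compound 1 and a number at least 6.0 degrees C higher (beyond the scatter) from compound 3 to compound 4, at least 11 degrees C apart, beyond the scatter of two such steps. On these data alone, the direction of the step is therefore tied to the core in these two pairs, but the true size of this rise stays unknown and two pairs give no rule for other cores: the limit of > 17 degrees C in this assay, at which 1 of the 4 values shown sits.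

Which part of the difference between the two cores turns the step around remains open. Also open, as far as these compounds go, is how pyridin-3-yl, on a carbon with a double bond to nitrogen, would behave on each core.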